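Swapping trifluoromethyl for oxazolyl on the piperidine ring

The source may report more compounds than this note shows. Statements on the series, on what has been measured and on what is new or still open speak of the compounds shown alone.

Of the compounds shown here, three have been tested in an assay on CHO cells for displacement of a labelled ligand from 5-hydroxytryptamine receptor 7 (Homo sapiens); on this read-out lower numbers stand for stronger inhibition and higher numbers for weaker inhibition. Compound 1, `O=S(=O)(c1ccccc1)C1(CCCN2CCCCC2)CCC1`, gives 2700 nM in this assay. Compound 2, `O=S(=O)(CCCCN1CCC2CCCCC2C1)c1ccccc1`, gives 96 nM. Compound 3, `CC(C)(CCCN1CCCC(C(F)(F)F)C1)S(=O)(=O)c1ccccc1`, gives 54 nM. Compound 3 and compound 2 sit within the usual scatter of each other, so their numbers cannot be told apart; compound 1 stands far higher, a gap well beyond the scatter, so compound 1 is clearly the weaker binder of the set.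

Compound 4, `CC(C)(CCCN1CCCC(c2cnco2)C1)S(=O)(=O)c1ccccc1`, has not yet been measured. It differs from compound 3 in one place: 1,3-oxazol-5-yl in place of trifluoromethyl on a saturated ring carbon. Within the data shown here, no step of this kind exists among the measured compounds, so no measured pair tells how the change plays out. The replacing group is larger and brings two acceptors, and compound 2 and compound 3 show that varied groups on the saturated ring are tolerated. A modest step in either direction, possibly none beyond the scatter, is expected as a 1.5-fold higher number from compound 3 to compound 4 (0.17 log units; within the scatter). Compound 4 is therefore estimated at 80 nM, within a range from 20 nM to 320 nM.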

Compound 4, inhibition constant: 15 nM
For compound 4 the middle estimate is 5.3-fold (0.73 log units) above the measured one; measured number below the stated range.
By their numbers in this assay, from the lowest: compound 4; then compounds 3 and 2 (each within the scatter of the next); then compound 1.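

In this assay, the step is a 3.6-fold lower number from compound 3 to compound 4 (0.56 log units; beyond the scatter), so this ring carbon, two ring bonds from the ring nitrogen, does more than tolerate a change of group: the replacement gives a real, if modest, gain in binding. The earlier compounds shown here had no matched pair to show this, and here a five-membered aromatic ring carrying hydrogen-bond acceptors takes the place of trifluoromethyl, which has none. No measurement bears on why the number falls.

This single swap changes the ring and the hetero atoms together, so the compounds shown leave open which of them matters; a phenyl group on the same carbon, with a ring but no hetero atoms, would begin to separate the two. Also open, going by these compounds, is how a small methyl group would fare at this position.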